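The source may hold more compounds than are shown below. What is called first, only, known or untested is meant among the compounds shown, and "the series" means these compounds.

Compound 1 `S=C(SCc1cn(Cc2ccc(Cl)c(Cl)c2)nn1)N1CCNCC1`: "not determined" (no result reported) in a functional assay on MGC-803 cells (Homo sapiens) for inhibition, read by MTT assay, with a stated time of 72 h; a higher number here means a weaker inhibitor, a lower number a stronger inhibitor. Compound 2 `O=C(OCc1ccccc1)N1CCN(C(=S)SCc2cn(Cc3ccc(Cl)c(Cl)c3)nn2)CC1`: 7140 nM. Compound 3 `CC(C)(C)OC(=O)N1CCN(C(=S)SCc2cn(CCOc3ccc4ccc(=O)oc4c3)nn2)CC1`: 67100 nM.

Compound 2 holds the lower of the two numbers recorded in this assay, and its gap to compound 3 lies beyond the usual scatter; compound 1 contributes no number. Compound 4 `O=C(OCc1ccccc1)N1CCN(C(=S)SCc2cn(Cc3ccccc3F)nn2)CC1` differs from compound 2 in one place: 2-fluorophenyl in place of 3,4-dichlorophenyl on a saturated chain carbon bound to an aromatic nitrogen. For the measured compounds named here, no measured pair in this set shows what such a change does, so the expected step from compound 2 to compound 4 rests on the change alone. A small shift toward a weaker result is expected, a 1.4-fold higher number from compound 2 to compound 4 (0.15 log units; within the scatter), though one that may well fall within the scatter. Compound 4 is therefore estimated at 10000 nM in this assay, between 3000 nM and 35000 nM.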

Compound 4, half-maximal inhibitory concentration: 5060 nM
For compound 4 the middle estimate is 2.0-fold (0.30 log units) above the measured one; the measured number falls inside the stated range.
By their numbers in this assay, from the lowest: compounds 4 and 2 (each within the scatter of the next); then compound 3.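

In this assay, for the compounds shown here, 2-fluorophenyl in place of 3,4-dichlorophenyl gives a 1.4-fold lower number from compound 2 to compound 4 (0.15 log units; within the scatter), the first reading of a change made at this position alone. On a saturated chain carbon bound to an aromatic nitrogen, the exchange of 3,4-dichlorobenzyl for 2-fluorobenzyl therefore leaves no readable difference, and the two chlorines are not needed for a number of this size. Nothing at hand offers an explanation for this outcome. On these data alone, it remains open whether an unsubstituted benzyl, or a benzyl carrying an amine or a carboxylic acid, would stay as close. A longer chain in place of the benzyl group is equally untested among these compounds.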